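A few compounds are considered here, and "the series" means these few. Any claim that something is new, unique, unknown or untested is made for them only; others in the source may bear on it.

Measured compounds:
- Compound 1, `COc1ccc(C(O)c2cn(C[C@H]3COC(C)(C)O3)nn2)c(OC)c1OC`: in a functional assay on B16 cells (Mus musculus) for cytotoxicity, read by MTT assay, with a stated time of 48 h (a lower number here means a stronger inhibitor, a higher number a weaker inhibitor), compound 1 gives > 100000 nM, a limit of the assay.
- Compound 2, `COc1ccc(C(O)c2cn(C[C@H]3COC(C)(C)O3)nn2)cc1`: in this assay compound 2 gives > 100000 nM, a limit.
- Compound 3, `COc1ccc(C(O)c2cn(Cc3cccc(OC)c3)nn2)cc1`: in this assay compound 3 gives > 100000 nM, a limit.

All three values sit at the same boundary, (the limit of > 100000 nM in this assay, at which 3 of the 3 values shown sit), so no ordering among them can be read. Compound 4, `COc1cccc(Cn2cc(C(O)c3ccc(OC)c(OC)c3OC)nn2)c1`, is not yet measured. It differs from compound 1 by 3-methoxyphenyl in place of 2,2-dimethyl-1,3-dioxolan-4-yl on a saturated chain carbon bound to an aromatic nitrogen. The same change, (3-methoxyphenyl in place of 2,2-dimethyl-1,3-dioxolan-4-yl on a saturated chain carbon bound to an aromatic nitrogen), links compound 2 to compound 3, where the two limits leave the step unreadable: a step that the two limits leave unreadable from compound 2 to compound 3. The two places are described in identical words, so the change is the same one made on a different core; the difference between the core of compound 1 and the core of compound 2 is not broken down here. With both ends of the measured step at the limit, the expectation for compound 4 in this assay is a comparable step, a step that the limit leaves unreadable from compound 1 to compound 4, most likely again at the boundary. Compound 4 is estimated at 150000 nM, within 30000 nM to 600000 nM.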

Compound 4, half-maximal inhibitory concentration: > 100000 nM
Compound 4: no number, only a limit; the forecaster's own chance of this, stated with the estimate: 85%; the middle value is on the limit's open side.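

In this assay compound 4 gives > 100000 nM, a limit and not a number. The step between compound 1 and compound 4 therefore cannot be read, and the series stays at one boundary: the limit of > 100000 nM in this assay, at which 4 of the 4 values shown sit.

The compounds shown leave open how strong any of the four is, and whether 3-methoxyphenyl or 2,2-dimethyl-1,3-dioxolan-4-yl makes any difference in this assay.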